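Substituent change on the shared core: compounds 1 to 3

This account rests on a few compounds, and the source may have more. Where it says the series, first, only, none or still open, it means among the compounds named here.

Compound 1 `Cc1csc(NC(=O)Cn2cc(-c3ccc(Cl)cc3)nn2)n1` gives 520 nM in a functional assay on BMDM cells (Mus musculus, strain C57BL/6) for inhibition, with a stated time of 2 days; a lower number here means a stronger inhibitor, a higher number a weaker inhibitor. For the measured compounds named here, compound 2 `Cc1csc(NC(=O)Cn2cc(-c3ccc(F)cc3)nn2)n1` gives 250 nM in this assay after a 2.1-fold lower number from compound 1 to compound 2 (0.32 log units; beyond the scatter), and so holds the lowest of the two numbers measured so far. Compound 3 `Cc1csc(NC(=O)Cn2cc(-c3ccc([N+](=O)[O-])cc3)nn2)n1` is not yet measured; it differs from compound 2 by nitro in place of fluoro on an aromatic carbon. Going by the values given here, the only measured step swaps one halogen for another and is modest; no measured step involves a nitro group, so nothing bears directly on this change. For compound 3 the expected step is a 1.4-fold higher number from compound 2 to compound 3 (0.15 log units; within the scatter), meaning no change beyond the scatter. The estimate for compound 3 is 350 nM, with a range from 120 nM to 1000 nM.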

Compound 3, half-maximal inhibitory concentration: 190 nM
Compound 3: middle estimate off by 1.8-fold (0.27 log units), on the high side; the measured number falls inside the stated range.
By their numbers in this assay, from the lowest: compounds 3 and 2 (each within the scatter of the next); then compound 1.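

At the aromatic carbon para to a large group, a group other than a halogen is accepted in this assay, with a 1.3-fold lower number from compound 2 to compound 3 (0.12 log units; within the scatter), so nitro and fluoro cannot be told apart here despite the added heavy atoms and hydrogen-bond acceptors. Against chloro the picture differs, with a 2.7-fold lower number from compound 1 to compound 3 (0.44 log units; beyond the scatter), which puts compound 3 with compound 2 on the lower side of compound 1. Nothing available explains these numbers.

From the compounds shown here alone, how an amine or a carboxylic acid would behave at this position remains open. The compounds shown also say nothing about other places on the shared core.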